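Swapping the dimethoxyphenyl end of compound 1

The source may report more compounds than this note shows. Statements on the series, on what has been measured and on what is new or still open speak of the compounds shown alone.

compound 1 `COc1ccc(-c2ccc(-c3ccc(-c4nc5cc(C)ccc5[nH]4)cc3)cc2)cc1OC`: 1310 nM
compound 2 `COc1cc(-c2ccc(-c3ccc(-c4nc5cc(C)ccc5[nH]4)cc3)cc2)cc(OC)c1OC`: 170 nM
compound 3 `COc1ccc(-c2ccc(-c3ccc(-c4nc5c(O)cccc5[nH]4)cc3)cc2)cc1OC`: 1110 nM

These three compounds were tested in a functional assay on Gurav cells (Homo sapiens) for inhibition, read by sulforhodamine B assay; on this read-out lower numbers stand for stronger inhibition of growth and higher numbers for weaker inhibition of growth. Compound 1 gives the highest number of the three, but its lead over compound 3 is not a real difference: the change is a 1.2-fold lower number from compound 1 to compound 3 (0.07 log units; within the scatter). The next compound, compound 4 `Cc1ccc2[nH]c(-c3ccc(-c4ccc(-c5ccc(C(F)(F)F)cc5)cc4)cc3)nc2c1`, keeps the core of compound 1 and replaces one end group, with 4-(trifluoromethyl)phenyl in place of 3,4-dimethoxyphenyl on an aromatic carbon.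

The most relevant evidence is a 7.7-fold lower number from compound 1 to compound 2 (0.89 log units; beyond the scatter), which adds a methoxy to the ring that leaves here. It shows that this ring can matter, and more methoxy gave a lower number. The other measured step changes the opposite end of the molecule and tells little about this swap. Going by the values given here, no measured compound carries trifluoromethyl, so the direction remains uncertain, and only a slight lean towards a higher number seems justified. The step expected in this assay is a 1.5-fold higher number from compound 1 to compound 4 (0.18 log units; within the scatter), so no clear change is expected. For compound 4 the estimated value is 2000 nM, with an expected range from 500 nM to 8000 nM.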

Compound 4, concentration for 50% growth inhibition: 12000 nM
Beside the measured number, compound 4's estimate is 6.0-fold (0.78 log units) below it; measured number outside the range, above it.
By their numbers in this assay, from the lowest: compound 2; then compounds 3 and 1 (each within the scatter of the next); then compound 4.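

In this assay, the swap at this position gives a 9.2-fold higher number from compound 1 to compound 4 (0.96 log units; beyond the scatter). The same end ring can therefore push the number up as well as down, the downward direction being a 7.7-fold lower number from compound 1 to compound 2 (0.89 log units; beyond the scatter). The two groups match in heavy atoms, yet 3,4-dimethoxyphenyl carries 2 hydrogen-bond acceptors and 4-(trifluoromethyl)phenyl carries 0, so equal heavy-atom count alone does not keep the number in place; no measurement here gives a reason for the rise.

The swap removes both methoxy groups and brings in trifluoromethyl in one move, so the compounds shown do not separate the loss from the gain. Also open, as far as these compounds go, is how this ring would respond to a single methoxy or to an amine at the place para to a large group.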